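Shortening the benzylamino chain on the shared core

The compounds below may be only part of what the source reports. "The series", "measured", "known", "first", "only" and "open" are said of these compounds alone.

Compound 1 `Cc1nc(Nc2ccccc2)c2cnn(-c3ccccc3)c2n1` and compound 2 `Cc1nc(NCc2ccccc2)c2cnn(-c3ccccc3)c2n1` share one core and differ only by benzyl in place of phenyl on a nitrogen on an aromatic ring. In a functional assay on G-361 cells (Homo sapiens) for cytotoxicity, read by sulforhodamine B assay (a higher number here means that more compound is tolerated, a lower number that less compound is tolerated), compound 1 reaches only a limit of the assay, > 100000 nM. In this assay compound 2 likewise stands at a limit, > 100000 nM. The step that the two limits leave unreadable from compound 1 to compound 2 is thus unreadable, and both values sit on the same ceiling (the limit of > 100000 nM in this assay, at which 2 of the 2 values shown sit). Compound 2 therefore stands at the upper edge of what this assay reports, with no numeric value behind it.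

Compound 3 `CCNc1nc(C)nc2c1cnn2-c1ccccc1` differs from compound 2 by methyl in place of phenyl on a saturated chain carbon bound to a nitrogen on an aromatic ring; cut one bond further out, this reads benzyl to ethyl, benzylamino to ethylamino. Within the data shown here, no measured step bears directly on this exchange, and the one measured step that the two limits leave unreadable from compound 1 to compound 2 offers no readable size. With both measured values at the same limit, no step beyond the scatter is expected in this assay in either direction. Compound 3 is expected to sit near 100000 nM, between 40000 nM and 300000 nM, most likely again reported as a limit. The expected step of a number no higher from compound 2 to compound 3 (the limit leaves the size open) is accordingly about nothing.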

Compound 3, concentration lethal to 50% of the cells: > 100000 nM
Compound 3 ended at the assay's limit; the forecaster's own chance of this, stated with the estimate: 80%; the middle value sits exactly at the limit.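

Compound 3 gives only a limit in this assay, > 100000 nM. The steps among compound 1, compound 2 and compound 3 cannot be read, as all three sit on one ceiling: the limit of > 100000 nM in this assay, at which 3 of the 3 values shown sit.

Still open, on these data alone, is whether the phenyl, benzyl and ethyl compounds differ at all in this assay, with no numeric value among the three.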